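Dimethylamino for pyrrolidin-1-yl in the chloro series

A few compounds are considered here, and "the series" means these few. Any claim that something is new, unique, unknown or untested is made for them only; others in the source may bear on it.

- compound 1 `Clc1nc2c(NCc3ccccc3)nc(N3CCNCC3)nc2nc1N1CCCC1`: 4000 nM
- compound 2 `Clc1nc2c(N3CCCC3)nc(N3CCNCC3)nc2nc1N1CCCC1`: 3100 nM
- compound 3 `CN(C)c1nc2nc(N3CCNCC3)nc(N3CCCC3)c2nc1Cl`: not yet measured

In a functional assay (Homo sapiens) for inhibition, read by sulforhodamine B assay, with a stated time of 3 days (a lower number here means a stronger inhibitor, a higher number a weaker inhibitor), compound 2 stands at 3100 nM, within the scatter of compound 1.

Compound 3 carries dimethylamino in place of pyrrolidin-1-yl on an aromatic carbon, ortho to a chloro group: dimethylamino in place of pyrrolidin-1-yl on an aromatic carbon. For the measured compounds named here, the only measured step, a 1.3-fold lower number from compound 1 to compound 2 (0.11 log units; within the scatter), concerns a different group and bears on this change only indirectly. It gives no ground for expecting a shift beyond the scatter in this assay. The expected change is a 1.1-fold higher number from compound 2 to compound 3 (0.05 log units; within the scatter) and no real separation. Compound 3 is estimated at 3500 nM, with an expected range from 1500 nM to 8000 nM.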

Compound 3, half-maximal inhibitory concentration: 5800 nM
Compound 3: the middle estimate sits 1.7-fold (0.22 log units) below what was measured, and the stated range covers the measured number.
By their numbers in this assay, from the lowest: compounds 2, 1 and 3 (each within the scatter of the next).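

On the aromatic carbon ortho to the chloro group, dimethylamino can stand in place of pyrrolidin-1-yl in this assay (a 1.9-fold higher number from compound 2 to compound 3 (0.27 log units; within the scatter)). For the compounds shown here, the ring of pyrrolidin-1-yl is therefore not required at this position for a number in this range, a point the earlier compounds could not address, as both carry that group here. No measured evidence bears on the reason for this result.

Still open, on these data alone, is whether a different group at this position, such as a primary amine, a methoxy group or a longer chain like dipropylamino, would shift the number beyond the scatter.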